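Bromo to Fluoro on the Shared Core: Compound 4

The source may hold more compounds than are shown below. What is called first, only, known or untested is meant among the compounds shown, and "the series" means these compounds.

Compound 1 `COc1ccc2[nH]cc(-c3nc(C(=O)Nc4cc(OC)c(OC)c(OC)c4)cs3)c2c1` gives > 100000 nM in a functional assay on MDA-MB-231 cells (Homo sapiens) for cytotoxicity, read by MTT assay, with a stated time of 48 h, in the absence of a further agent (on this read-out higher numbers stand for weaker inhibition and lower numbers for stronger inhibition), which is a limit of the assay and not a number.
Compound 2 `O=C(Nc1ccccc1)c1csc(-c2c[nH]c3ccccc23)n1` gives 79400 nM in this assay.
Compound 3 `COc1cc(NC(=O)c2csc(-c3c[nH]c4ccc(Br)cc34)n2)cc(OC)c1OC` gives > 100000 nM in this assay, again a limit and not a number.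

Compound 3 therefore stands at the edge of what this assay can report: its value is a limit, and it shares that position with compound 1, as the limit of > 100000 nM in this assay, at which 2 of the 3 values shown sit, records. Only compound 2 gives a measured number, and it lies not far from that same edge.

Compound 4 `COc1cc(NC(=O)c2csc(-c3c[nH]c4ccc(F)cc34)n2)cc(OC)c1OC` differs from compound 3 in one place: fluoro in place of bromo on an aromatic carbon. Within the data shown here, the only measured step between two compounds that differ in one place is a step that the two limits leave unreadable from compound 1 to compound 3. Both of its ends are limits, so its size cannot be read. Among the measured compounds shown here, there is thus no measured step that shows how a change at this aromatic carbon moves the read-out in this assay.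

With nothing to point the other way, compound 4 is expected to sit where compound 3 sits, so the step of a number no higher from compound 3 to compound 4 (the limit leaves the size open) is estimated as none beyond the scatter. Compound 4 is estimated at 100000 nM in this assay, with a range from 40000 nM to 250000 nM, and a limit rather than a number is the most likely outcome.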

Compound 4, half-maximal inhibitory concentration: > 100000 nM
Compound 4 gave a limit, no number; the forecaster's own chance of this, stated with the estimate: 65%; the middle value lies on the limit itself.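

No new step can be read: compound 1, compound 3 and compound 4 each give only a limit, so the steps from compound 3 to compound 4 and from compound 1 to compound 4 have no size. The compounds shown leave open whether methoxy, bromo or fluoro at this aromatic carbon changes the read-out in this assay at all, with most results resting on one value: the limit of > 100000 nM in this assay, at which 3 of the 4 values shown sit.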